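Trifluoromethyl for trifluoromethoxy at the limit of the assay

The source may hold more compounds than are shown below. What is called first, only, known or untested is meant among the compounds shown, and "the series" means these compounds.

In an ADME assay on BJ cells (Homo sapiens) for cytotoxicity, with a stated time of 72 h (on this read-out higher numbers stand for an effect only at larger amounts of compound and lower numbers for an effect already at smaller amounts), compound 1 `CCOc1ccc(/C=C/[C@@](C)(/C=C/c2ccc(O)cc2)CCC=C(C)C)cc1` gives > 36600 nM as a limit of the assay. Compound 2 `C=C[C@@](C)(/C=C/c1ccc(Nc2ccc(OC)c(OC)c2)cc1)CCC=C(C)C` gives > 36600 nM, which is also a limit. Compound 3 `C=C[C@@](C)(/C=C/c1ccc(Nc2ccc(OC(F)(F)F)cc2)cc1)CCC=C(C)C` stands at > 36600 nM, again a limit and not a number. Among the compounds with values here, the series so far therefore shows only (the limit of > 36600 nM in this assay, at which 3 of the 3 values shown sit), and no step between measured compounds is available.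

Compound 4 `C=C[C@@](C)(/C=C/c1ccc(Nc2ccc(C(F)(F)F)cc2)cc1)CCC=C(C)C` carries trifluoromethyl in place of trifluoromethoxy on an aromatic carbon, para to a large group (trifluoromethyl in place of trifluoromethoxy on an aromatic carbon), and the rest of the structure stays the same. The expectation rests on compound 3 and its limit of > 36600 nM, which it shares with the two other measured compounds. The expected step of a number no higher from compound 3 to compound 4 (the limit leaves the size open) in this assay is estimated to stay within the scatter, with no direction favoured. For compound 4 the estimated value is 36600 nM, with an expected range from 18000 nM to 60000 nM, and another report as a limit is expected.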

Compound 4, half-maximal effective concentration: > 36600 nM
Compound 4 ended at the assay's limit; the forecaster's own chance of this, stated with the estimate: 80%; the middle value lies on the limit itself.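

Within the data shown here, compound 3 and compound 4 both sit at a limit in this assay, so no step between them can be read. The compounds shown leave open whether trifluoromethyl and trifluoromethoxy differ at all in this assay, and at what concentration any effect appears: the limit of > 36600 nM in this assay, at which 4 of the 4 values shown sit.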